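Compound 3 to compound 4: a step from a limit

The source may hold more compounds than are shown below. What is called first, only, known or untested is meant among the compounds shown, and "the series" means these compounds.

Values in a functional assay on Jurkat cells (Homo sapiens) for cytotoxicity, with a stated time of 72 h (on this read-out higher numbers stand for an effect only at larger amounts of compound and lower numbers for an effect already at smaller amounts), each of them a limit:
Compound 1 `C=C[C@@](C)(/C=C/c1ccc(OCc2ccccc2)cc1)CCC=C(C)C`: > 49000 nM
Compound 2 `C=C[C@@](C)(/C=C/c1ccc(OS(=O)(=O)C(F)(F)F)cc1)CCC=C(C)C`: > 49000 nM
Compound 3 `C=C[C@@](C)(/C=C/c1ccc(O)cc1)CCC1OC1(C)C`: > 49000 nM

In this assay compound 3 has no number, only the limit > 49000 nM. It shares this position with the other two compounds, as the limit of > 49000 nM in this assay, at which 3 of the 3 values shown sit, shows.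

Compound 4 `C=C[C@@](C)(/C=C/c1ccc(O)cc1)CCC=O` keeps the shared core and differs at the end of the chain: formyl in place of 3,3-dimethyloxiran-2-yl on a saturated chain carbon, three bonds along the chain from two double-bonded chain carbons. Formyl stands in place of 3,3-dimethyloxiran-2-yl on a saturated chain carbon.

One measured step exists, a step that the two limits leave unreadable from compound 1 to compound 2. It lies on an oxygen on an aromatic ring rather than on the chain, and its size cannot be read, so it gives neither a size nor a direction for this change. Within the data shown here, no measured compound carries formyl. The expectation therefore rests on compound 3 at > 49000 nM and on (the limit of > 49000 nM in this assay, at which 3 of the 3 values shown sit), and no step beyond the scatter is expected in this assay. The estimated step is a step that the limit leaves unreadable from compound 3 to compound 4. The assay may well report only a limit again.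

For compound 4 the estimated value is 50000 nM, with an expected range from 20000 nM to 100000 nM.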

Compound 4, half-maximal effective concentration: > 49000 nM
Compound 4 was reported as a limit; the forecaster's own chance of this, stated with the estimate: 75%; the middle value is on the limit's open side.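

In this assay compound 4, like compound 3, is reported only as a limit, so no step can be read between compound 3 and compound 4: the limit of > 49000 nM in this assay, at which 4 of the 4 values shown sit. The compounds shown leave open how far beyond that limit any of them lies, and whether any change on the shared core would give a measurable number.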